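A Shortened Chain on a Core That Shows No Inhibition

The source may report more compounds than this note shows. Statements on the series, on what has been measured and on what is new or still open speak of the compounds shown alone.

Compound 3 `CCCc1nnc(S)n2c(CCC)nc(C)c12` is the starting point. In a functional assay for inhibition, with Homo sapiens as the target (on this read-out higher numbers stand for weaker inhibition and lower numbers for stronger inhibition), compound 3 gives > 48000 nM, which is a limit of the assay rather than a number. Compound 1 `CCCc1nc(C)c2c(C)nnc(SC)n12` stands at > 48000 nM in this assay, likewise a limit. Compound 2 `Cc1nnc(S)n2c(C)nc(C)c12` in this assay reaches only > 48000 nM, again a limit. All three share (the limit of > 48000 nM in this assay, at which 3 of the 3 values shown sit), and compound 3 sits there alongside the others. Compound 4 `CCCc1nc(C)c2c(C)nnc(S)n12` differs from compound 3 in one place: hydrogen in place of ethyl on a saturated chain carbon bound to an aromatic carbon. Going by the values given here, no measured pair differs in one place, and no size of step is known from the data. The expected step is a step that the limit leaves unreadable from compound 3 to compound 4, none beyond the scatter. Compound 4 is therefore estimated at 60000 nM, with a range from 20000 nM to 200000 nM, and most likely again only a limit.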

Compound 4, half-maximal inhibitory concentration: 45000 nM
Estimate against measurement, compound 4: 1.3-fold (0.12 log units) above; the range from low to high includes it.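

In this assay, compound 4, with propyl to methyl as the change from compound 3, is the only one of the four compounds to give a number rather than a limit: the limit of > 48000 nM in this assay, at which 3 of the 4 values shown sit.

Hydrogen in place of ethyl on a saturated chain carbon bound to an aromatic carbon gives an at least 1.0-fold lower number from compound 3 to compound 4 (0.02 log units; that floor lies within the scatter), and the reverse swap gives an at least 1.0-fold lower number from compound 2 to compound 4 (0.02 log units; that floor lies within the scatter). Hydrogen in place of methyl on a sulfur gives an at least 1.0-fold lower number from compound 1 to compound 4 (0.02 log units; that floor lies within the scatter), so none of these changes is shown to shift inhibition beyond the scatter.

On these data alone, whether an amine or a carboxylic acid on that chain, or a longer chain on the sulfur, would give clearly stronger inhibition remains open.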